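This account rests on a few compounds, and the source may have more. Where it says the series, first, only, none or still open, it means among the compounds named here.

Working notes on the series, read in a functional assay with Mus musculus as the target; a lower number here means that less compound is needed, a higher number that more compound is needed for the effect. Compound 1 (`CCCn1c(=O)n(C2OC(COP(=O)(O)O)[C@@H](O)[C@H]2O)c2nc(N)nc(O)c21`) gives 82 uM, and compound 3 (`C=CCn1c(=S)n(C2OC(COC(C)=O)[C@H]3OC(C)(C)O[C@@H]23)c2nc(N)nc(O)c21`) gives 50 uM. Compound 2 (`COc1ccc(Cn2c(=O)n(C3OC(CO)[C@@H](O)[C@H]3O)c3nc(N)nc(O)c32)cc1`) gives 2 uM, the lowest of the three numbers, with the other two lying beyond the scatter above it.

Compound 4 (`CCCCn1c(=O)n(C2OC(CO)[C@@H](O)[C@H]2O)c2nc(N)nc(O)c21`) has not yet been measured in this assay. Its structure departs from compound 2 at one place: propyl in place of 4-methoxyphenyl on a saturated chain carbon bound to an aromatic nitrogen. This puts propyl in place of 4-methoxyphenyl on a saturated chain carbon bound to an aromatic nitrogen, so 4-methoxybenzyl becomes butyl.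

Within the data shown here, no measured pair isolates this change, as compound 1 and compound 3 each differ from compound 2 in more than one place. The guide is therefore thin: compound 2 at 2 uM carries 4-methoxybenzyl, while neither compound 1 at 82 uM nor compound 3 at 50 uM does, and both of these stand higher. A rise beyond the scatter is expected, with the expected step of a 7.5-fold higher number from compound 2 to compound 4 (0.88 log units; beyond the scatter). For compound 4 the estimated value is 15 uM, with an expected range of 3 uM to 60 uM.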

Compound 4, concentration for half-maximal effect: 100 uM
The estimate for compound 4 lay 6.7-fold (0.82 log units) below the measured number; the measured number lies above the stated range.
By their numbers in this assay, from the lowest: compound 2; then compounds 3, 1 and 4 (each within the scatter of the next).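

Among these compounds, replacing 4-methoxybenzyl with butyl on the shared core gives a 50-fold higher number from compound 2 to compound 4 (1.70 log units; beyond the scatter) in this assay, and this is the one pair that isolates a single change. The position is therefore not indifferent to its substituent: on a saturated chain carbon bound to an aromatic nitrogen, 4-methoxyphenyl and propyl are far from interchangeable in this read-out. Nothing available accounts for the size of this step.

The change removes the aromatic ring and the methoxy group together, so the compounds shown leave open how the step divides between them, a question that plain benzyl would address. They also leave open whether a longer chain, such as hexyl, would stay with butyl or move towards 4-methoxybenzyl.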